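The compounds below may be only part of what the source reports. "The series", "measured", "known", "first", "only" and "open" are said of these compounds alone.

Compound 1 `C/C(=N\NC(=O)c1cccc(S(=O)(=O)N2CCOCC2)c1)c1cccc(N)c1` and compound 2 `C/C(=N\NC(=O)c1cccc(S(=O)(=O)N2CCOCC2)c1)c1cc(O)ccc1O` share a core and differ only in the aryl group carried on the carbon with a double bond to nitrogen. In a functional assay on MCF7 cells (Homo sapiens) for antiproliferative activity, read by MTT assay, with a stated time of 72 h (on this read-out higher numbers stand for weaker inhibition and lower numbers for stronger inhibition), compound 1 gives > 100000 nM, which is a limit of the assay rather than a number. In this assay compound 2 gives > 100000 nM, again a limit. The step that the two limits leave unreadable from compound 1 to compound 2 therefore cannot be read, since both values sit at the limit of > 100000 nM in this assay, at which 2 of the 2 values shown sit. Compound 2 thus stands at the ceiling of what this assay reports, with no number of its own.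

Compound 3 `C/C(=N\NC(=O)c1cccc(S(=O)(=O)N2CCOCC2)c1)c1cccc(N)c1O` has not yet been measured. It differs from compound 2 in one place: 3-amino-2-hydroxyphenyl in place of 2,5-dihydroxyphenyl on a carbon with a double bond to nitrogen. Among the measured compounds shown here, no measured step bears on this change, as the only step available, a step that the two limits leave unreadable from compound 1 to compound 2, is unreadable, and the two values shown both sit at the limit of > 100000 nM in this assay, at which 2 of the 2 values shown sit. With nothing pointing to activity, the expected step of a number no higher from compound 2 to compound 3 (the limit leaves the size open) is none beyond the scatter. Compound 3 is therefore estimated at 100000 nM, with a range from 30000 nM to 300000 nM, most likely reported again only as a limit.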

Compound 3, half-maximal inhibitory concentration: 1010 nM
Compound 3: middle estimate off by 99-fold (2.00 log units), on the high side; the measured number lies below the stated range.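

In this assay, 3-amino-2-hydroxyphenyl in place of 2,5-dihydroxyphenyl on a carbon with a double bond to nitrogen gives an at least 99-fold lower number from compound 2 to compound 3 (1.99 log units; beyond the scatter), so the aryl group at this place can decide whether the shared core gives a readable number at all. Hydroxy in place of hydrogen on an aromatic carbon of the 3-aminophenyl group gives an at least 99-fold lower number from compound 1 to compound 3 (1.99 log units; beyond the scatter), and among the three compounds only the group that carries both amino and hydroxy reaches a number, while the group with amino alone and the group with two hydroxy groups stay at a limit. Both steps are minimum sizes only, because each starts from a value that is a limit of the assay and not a number: the limit of > 100000 nM in this assay, at which 2 of the 3 values shown sit.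

The compounds shown leave open whether the number would hold with a methoxy group in place of the hydroxy group or a dimethylamino group in place of the amino group. They also leave open whether amino and hydroxy would give a similar number in another arrangement on the same ring.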